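A few compounds are considered here, and "the series" means these few. Any claim that something is new, unique, unknown or untested is made for them only; others in the source may bear on it.

The account begins with compound 1, `COc1cccnc1-c1cc(Cl)ccc1NS(=O)(=O)c1ccc(C(C)(C)C)cc1`. In a functional assay on isolated protein for antagonist activity at C-C chemokine receptor type 9 (Homo sapiens), read by calcium flux, with a stated time of 10 min (on this read-out higher numbers stand for weaker inhibition and lower numbers for stronger inhibition), compound 1 gives 958 nM, the highest of the three numbers measured: compound 2, `CC(C)(C)c1ccc(S(=O)(=O)Nc2ccc(Cl)cc2-c2c(O)ccc[n+]2[O-])cc1`, gives 491 nM, and compound 3, `CC(C)(C)c1ccc(S(=O)(=O)Nc2ccc(Cl)cc2-c2nc(N)ncc2O)cc1`, gives 4 nM. The change from compound 1 to compound 4, `CC(C)(C)c1ccc(S(=O)(=O)Nc2ccc(Cl)cc2-c2nccnc2NCCO)cc1`, is a group of 10 heavy atoms (6 carbon, 3 nitrogen, 1 oxygen; one six-membered aromatic ring with 2 hetero atoms) in place of a group of 8 heavy atoms (6 carbon, 1 nitrogen, 1 oxygen; one six-membered aromatic ring with 1 hetero atom), on an aromatic carbon. Within the data shown here, two measured steps bear on it, each replacing the same group on the same aromatic carbon of the shared core. The step of a 2.0-fold lower number from compound 1 to compound 2 (0.29 log units; within the scatter) shows that exchanging one six-membered aromatic ring with one hetero atom for another can leave the number essentially where it is. The step of a 240-fold lower number from compound 1 to compound 3 (2.38 log units; beyond the scatter) shows that a six-membered aromatic ring with two hetero atoms can bring a large fall. The group entering compound 4 likewise holds two hetero atoms in its six-membered aromatic ring, so a large step downward is expected, with caution since only compound 3 with 4 nM supports it. Compound 4 is therefore expected to give 40 nM, within 8 nM to 250 nM. This estimate means an expected 24-fold lower number from compound 1 to compound 4 (1.38 log units; beyond the scatter).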

Compound 4, half-maximal inhibitory concentration: 34 nM
Beside the measured number, compound 4's estimate is 1.2-fold (0.07 log units) above it; the measured number falls inside the stated range.
By their numbers in this assay, from the lowest: compound 3; then compound 4; then compounds 2 and 1 (each within the scatter of the next).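

Compound 4 shows that the large fall at this aromatic carbon in this assay is not tied to the group in compound 3: a second group, with a six-membered aromatic ring holding two hetero atoms, gives a 28-fold lower number from compound 1 to compound 4 (1.45 log units; beyond the scatter) and also a 14-fold lower number from compound 2 to compound 4 (1.16 log units; beyond the scatter). The two such groups are not equivalent, though, as the series shows an 8.5-fold higher number from compound 3 to compound 4 (0.93 log units; beyond the scatter), so the count of ring hetero atoms alone does not set the number among these compounds. Nothing measured here accounts for any of these steps.

Compounds 3 and 4 differ in more than one feature of the entering group, so the shown compounds cannot say which feature carries that gap. Also open, going by these compounds, is how the number would respond to a longer chain or a carboxylic acid on the ring of compound 4.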